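Carbamoyl to methyl on the fused aromatic ring

The compounds below may be only part of what the source reports. "The series", "measured", "known", "first", "only" and "open" are said of these compounds alone.

Measured so far in an assay on HEK293 cells for binding affinity to 5-hydroxytryptamine receptor 7 (Homo sapiens), read by radioligand binding, tested at 1 uM; on this read-out lower numbers stand for less inhibition and higher numbers for more inhibition at the one concentration tested (going by the name of the read-out):
- compound 1 `Brc1ccc2ccn(CCN3CCN4CCCCC4C3)c2c1`: 78%
- compound 2 `CN1CCCN(CCn2ccc3cccc(Br)c32)CC1`: 18%
- compound 3 `CN1CCCN(CCn2ccc3ccc(C(N)=O)cc32)CC1`: 33%

Compound 3 stands second highest of the three numbers in this assay. Its nearest neighbour is compound 2, whose number is lower by a gap beyond the scatter; compound 1 is furthest, with a number higher by a gap well beyond the scatter. Within the data shown here, compound 2 and compound 3 share the same amine side chain, so the spread between them comes from the substituent on the fused ring alone; no step between them is counted here.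

The next compound, compound 4 `Cc1ccc2ccn(CCN3CCCN(C)CC3)c2c1`, differs from compound 3 in one place: methyl in place of carbamoyl on an aromatic carbon, on an aromatic carbon of a six-membered aromatic ring of carbon only, part of a fused system of two rings.

Among the measured compounds shown here, no measured pair isolates this change. With compound 3 at 33% and the carbamoyl only exchanged for a methyl, the step is expected to be small, of uncertain direction, and possibly within the scatter: a number 5 percentage points higher from compound 3 to compound 4 (within the scatter). Compound 4 is therefore estimated at 38%, within a range from 15% to 62%.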

Compound 4, a percentage reported as inhibition, at one concentration (the size of the read-out at that concentration, not a potency): 62%
The estimate for compound 4 lay 24 percentage points below the measured number; low and high end bracket the measured number.
By their numbers in this assay, from the lowest: compound 2; then compound 3; then compound 4; then compound 1.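

In this assay the exchange of carbamoyl for methyl on an aromatic carbon of the six-membered aromatic ring gives a number 29 percentage points higher from compound 3 to compound 4 (beyond the scatter) with the amine side chain unchanged, so this position is sensitive to the group it carries. The step goes with the loss of 1 hydrogen-bond donor and 1 hydrogen-bond acceptor, but a single pair cannot show that these counts drive the change. No measurement at hand explains the step.

As far as these compounds go, whether the higher number comes from losing the carbamoyl or from gaining the methyl remains open, and a bare hydrogen, a chlorine or a methoxy group on the same carbon would help separate the two. Also open, from the compounds shown here alone, is whether the same exchange gives a similar step with the side chain of compound 1.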